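Replacing furan-2-yl with 4-methoxyphenyl in compound 4

A few compounds are considered here, and "the series" means these few. Any claim that something is new, unique, unknown or untested is made for them only; others in the source may bear on it.

In a functional assay on THP-1 cells (Homo sapiens) for cytotoxicity, read by sulforhodamine B assay, with a stated time of 48 h (a lower number here means a stronger inhibitor, a higher number a weaker inhibitor), compound 3 `COc1cc(/C=C/C(=O)/C=C/c2ccco2)ccc1OCc1cn(CCOc2cc(=O)oc3ccccc23)nn1` gives 7870 nM. That value lies within the scatter of compound 2 `COc1cc(/C=C/C(=O)/C=C/c2cccs2)ccc1OCc1cn(CCOc2cc(=O)oc3ccccc23)nn1` at 7140 nM and of compound 1 `COc1cc(/C=C/C(=O)/C=C/c2cccc3ccccc23)ccc1OCc1cn(CCOc2cc(=O)oc3ccccc23)nn1` at 4480 nM. Compound 4 `COc1ccc(/C=C/C(=O)/C=C/c2ccc(OCc3cn(CCOc4cc(=O)oc5ccccc45)nn3)c(OC)c2)cc1` has not been measured yet, and it differs from compound 3 by a single swap: 4-methoxyphenyl in place of furan-2-yl on a double-bonded chain carbon bound to a double-bonded chain carbon. Three exchanges among naphthalen-1-yl, thiophen-2-yl and furan-2-yl at the same place bear on this swap. From the compounds shown here alone, with a 1.6-fold higher number from compound 1 to compound 2 (0.20 log units; within the scatter), a 1.8-fold higher number from compound 1 to compound 3 (0.24 log units; within the scatter) and a 1.1-fold higher number from compound 2 to compound 3 (0.04 log units; within the scatter) all within the scatter, no step beyond the scatter is expected in this assay, although 4-methoxyphenyl itself is untested there. The expected result is a 1.3-fold lower number from compound 3 to compound 4 (0.12 log units; within the scatter). Compound 4 is estimated at 6000 nM, with an expected range of 2700 nM to 13000 nM.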

Compound 4, half-maximal inhibitory concentration: 7410 nM
For compound 4 the middle estimate is 1.2-fold (0.09 log units) below the measured one, and the stated range covers the measured number.
By their numbers in this assay, from the lowest: compounds 1, 2, 4 and 3 (each within the scatter of the next).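

In this assay the 4-methoxyphenyl group, with a six-membered aromatic ring of carbon only, stays level with the other three groups (a 1.1-fold lower number from compound 3 to compound 4 (0.03 log units; within the scatter); a 1.0-fold higher number from compound 2 to compound 4 (0.02 log units; within the scatter); a 1.7-fold higher number from compound 1 to compound 4 (0.22 log units; within the scatter)). This position on a double-bonded chain carbon therefore accepts a ring carrying a methoxy group, with 8 heavy atoms against 5 in furan-2-yl, without a step beyond the scatter. Nothing available explains why these four compounds sit so close together. Still open, from the compounds shown here alone, is whether an amine or a carboxylic acid at this place, or a longer chain instead of a ring, would produce a step beyond the scatter.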